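The source may report more compounds than this note shows. Statements on the series, on what has been measured and on what is new or still open speak of the compounds shown alone.

In a functional assay on the whole organism (strain albino) for inhibition, with Rattus norvegicus as the target, read by paw edema, with a stated time of 2 h, at a dose of 0.28 mmol/kg by the oral route (a higher number here means more inhibition at the dose given (going by the name of the read-out), a lower number less inhibition), three compounds have been measured so far:

Compound 1, `CCn1c(SCC(=O)c2ccccc2)nnc1-c1ccc(OC)cc1`: 60%
Compound 2, `CCn1c(SCC(=O)c2ccccc2)nnc1-c1cc(OC)c(OC)c(OC)c1`: 41%
Compound 3, `CCn1c(SC/C(=N/O)c2ccccc2)nnc1-c1ccc(OC)c(OC)c1`: 67%

Compound 3 gives the highest of the three numbers. Its nearest neighbour is compound 1, and the gap between them lies within the usual scatter, so those two cannot be told apart with confidence. Compound 2 lies furthest from compound 3, and that gap is beyond the scatter, so compound 3 stands clearly above compound 2 in this assay.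

Compound 4, `CCn1c(SCC(=O)c2ccccc2)nnc1-c1ccc(OC)c(OC)c1`, has not yet been measured. It differs from compound 3 in one place: a group of 8 heavy atoms (7 carbon, 1 oxygen; one six-membered aromatic ring of carbon only) in place of a group of 9 heavy atoms (7 carbon, 1 nitrogen, 1 oxygen; one six-membered aromatic ring of carbon only), on a saturated chain carbon bound to a sulfur. The benzoyl that enters is the group compounds 1 and 2 already carry at that place, so compound 4 joins their series while keeping the outer ring of compound 3. Among the measured compounds shown here, no measured pair shows this exact change, so the size of the step can only be guessed from the neighbours. Compound 1 with 60% and compound 2 with 41% bracket the benzoyl compounds, and compound 4 is expected to fall between them. The expected step is a number 15 percentage points lower from compound 3 to compound 4 (beyond the scatter), a downward move of moderate size, close to the edge of the scatter. For compound 4 the estimate is 52%, with a range from 38% to 66%.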

Compound 4, a percentage reported as inhibition, in the whole organism at one dose (the size of the read-out at that dose, not a potency): 55%
Compound 4: the middle estimate sits 3 percentage points below what was measured, and the stated range covers the measured number.
By their numbers in this assay, from the lowest: compound 2; then compounds 4, 1 and 3 (each within the scatter of the next, the first and the last beyond it).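

Swapping the group of compound 3 for benzoyl on a saturated chain carbon bound to a sulfur gives, in this assay, a number 12 percentage points lower from compound 3 to compound 4 (beyond the scatter). Among the compounds shown here, this is the first direct reading at this position, and it shows that the number responds when the group with a hydrogen-bond donor leaves and benzoyl, which has none, enters. With benzoyl kept, the outer ring gives two different answers: hydrogen in place of methoxy on an aromatic carbon gives a number 14 percentage points higher from compound 2 to compound 4 (beyond the scatter), whereas methoxy in place of hydrogen on an aromatic carbon gives a number 5 percentage points lower from compound 1 to compound 4 (within the scatter), so only the first of these two changes can be told from no change at all.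

Nothing available here explains any of these steps. Going by these compounds, it remains open whether the group that left compound 3 would give a similar step on the outer rings of compound 1 or compound 2, and how an amine, a carboxylic acid or a longer chain in place of benzoyl at this position, or an ethoxy group in place of a methoxy on the ring, would read out.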